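From compound 2 to compound 3: fluoro gives way to hydrogen

A few compounds are considered here, and "the series" means these few. Any claim that something is new, unique, unknown or untested is made for them only; others in the source may bear on it.

For the measured compounds named here, in an ADME assay on HaCaT cells (Homo sapiens) for inhibition, read by sulforhodamine B assay, with a stated time of 48 h (a lower number here means a stronger inhibitor of growth, a higher number a weaker inhibitor of growth), compound 1 `CCOC(=O)c1nn(-c2ccccc2)c(-c2ccc(F)cc2)c1CNC(C)(C)C` gives two entries (74500 nM; 32900 nM (2 entries)) and is the only compound here with measured numbers. Compound 2 `CC(C)(C)NCc1c(C(=O)O)nn(-c2ccccc2)c1-c1ccc(F)cc1` stands at a limit of the assay and not at a number (> 680000 nM), and one further entry for it also carries no single number.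

Compound 3 `CC(C)(C)NCc1c(C(=O)O)nn(-c2ccccc2)c1-c1ccccc1` differs from compound 2 in one place: hydrogen in place of fluoro on an aromatic carbon, para to a large group, so that 4-fluorophenyl becomes phenyl (hydrogen in place of fluoro on an aromatic carbon). In this assay, going by the values given here, no measured step shows what this exchange does. The estimated move is a step that the limit leaves unreadable from compound 2 to compound 3 and it is expected to stay within the usual scatter, with neither direction favoured. The expectation leans on compound 2 and its limit (> 680000 nM), so compound 3 may well be reported only as a limit too. For compound 3 the expected value is 700000 nM as a working estimate (estimated range 300000 nM to 1500000 nM).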

Compound 3, concentration for 50% growth inhibition: > 716000 nM
Compound 3 was reported as a limit; the forecaster's own chance of this, stated with the estimate: 70%; middle value at least 1.0-fold (0.00 log units) from the limit.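

Compound 2 and compound 3 both stand only at limits in this assay, and no step can be read between them. The compounds shown leave open what the change from 4-fluorophenyl to phenyl does to growth inhibition, and where either compound would fall as a single measured number.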